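The source may hold more compounds than are shown below. What is called first, only, known or untested is meant among the compounds shown, and "the series" means these compounds.

Measured compounds and their values in a functional assay on ACHN cells (Homo sapiens) for inhibition, read by sulforhodamine B assay, with a stated time of 48 h; a higher number here means that more compound is tolerated, a lower number that less compound is tolerated:

compound 1 `COc1cc(-c2nn(-c3cccc(NC(=O)c4cccc(C(F)(F)F)c4)c3)cc2-c2ccncc2)ccc1Cl` — compound 1 reaches only the limit of > 50000 nM
compound 2 `COc1cc(-c2nn(-c3cccc(NC(=O)Nc4ccc(Cl)c(Cl)c4)c3)cc2-c2ccncc2)ccc1Cl` — compound 2 reaches only the limit of > 50000 nM
compound 3 `COc1cc(-c2nn(-c3cccc(NC(=O)c4ccc(Cl)c(C(F)(F)F)c4)c3)cc2-c2ccncc2)ccc1Cl` — compound 3 reaches only the limit of > 32500 nM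

None of the three values is a number; each is a limit. Compound 3 sits at the limit of > 32500 nM in this assay, at which 1 of the 3 values shown sits, while the other two sit at the limit of > 50000 nM in this assay, at which 2 of the 3 values shown sit. Every comparison between them is therefore blind: a step that the two limits leave unreadable from compound 1 to compound 2, a step that the two limits leave unreadable from compound 1 to compound 3 and a step that the two limits leave unreadable from compound 2 to compound 3 all fall between two limits and give no size and no direction.

Compound 4 `COc1cc(-c2nn(-c3cccc(NC(=O)Nc4ccc(Cl)c(C(F)(F)F)c4)c3)cc2-c2ccncc2)ccc1Cl` is the next member: (4-chloro-3-(trifluoromethyl)phenyl)amino in place of 4-chloro-3-(trifluoromethyl)phenyl on a carbonyl carbon. Among the measured compounds shown here, the only precedent for exchanging an aryl amide for an aryl urea on this core is the pair from compound 1 to compound 2, and that step is unreadable, as noted. Nothing in the series shows any member reaching a number in this assay, so the expectation for compound 4 is again a limit rather than a readable value, with no step beyond the scatter expected in a step that the limit leaves unreadable from compound 3 to compound 4. Compound 4 is thus estimated at 50000 nM in this assay, within 20000 nM to 100000 nM.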

Compound 4, concentration lethal to 50% of the cells: > 32500 nM
Compound 4 was reported as a limit (the forecaster's own chance of this, stated with the estimate: 85%); the middle value is on the limit's open side.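

In this assay compound 4 gives > 32500 nM, which is a limit and not a number. Its steps to compound 1, compound 2 and compound 3 cannot be read. The compounds shown leave open whether any change on the carbonyl carbon alters the value in this assay.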